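This account rests on a few compounds, and the source may have more. Where it says the series, first, only, none or still open, it means among the compounds named here.

Among the compounds with values here, in a functional assay on M21 cells (Homo sapiens) for inhibition, read by sulforhodamine B assay, with a stated time of 48 h (a higher number here means a weaker inhibitor of growth, a lower number a stronger inhibitor of growth), three compounds have numbers so far. Compound 1 (`c1ccc(COc2ccc(NC3=NCCO3)cc2)cc1`) gives 15900 nM, compound 2 (`O=C(CCl)NC(=O)Nc1ccc(OC2CCCC2)cc1`) gives 2900 nM, and compound 3 (`O=C(CCl)NC(=O)Nc1ccc(Oc2ccccc2)cc1`) gives 4200 nM. On these numbers compound 3 cannot be told apart from compound 2, whereas the value of compound 1 is higher than that of compound 3 by a gap beyond the scatter.

Compound 4 (`O=C(CCl)NC(=O)Nc1ccc(OCc2ccccc2)cc1`) has not been measured. It keeps the rest of compound 3 and carries benzyl in place of phenyl on an oxygen on an aromatic ring.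

Within the data shown here, only one measured step changes the group at that same place, with phenyl in place of cyclopentyl: a 1.4-fold higher number from compound 2 to compound 3 (0.16 log units; within the scatter). That single step stays within the scatter, so it gives no sign that this place responds strongly to a change of group, although it is thin evidence. Among the measured compounds shown here, compound 1 also carries benzyl on such an oxygen, but the rest of its structure differs and no measured step connects it to compound 4.

No step beyond the scatter is therefore expected in this assay. The expected step is a 1.2-fold lower number from compound 3 to compound 4 (0.08 log units; within the scatter). For compound 4 the estimated value is 3500 nM, within an expected range of 1500 nM to 8000 nM.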

Compound 4, concentration for 50% growth inhibition: 5100 nM
The estimate for compound 4 lay 1.5-fold (0.16 log units) below the measured number; the range from low to high includes it.
By their numbers in this assay, from the lowest: compounds 2, 3 and 4 (each within the scatter of the next); then compound 1.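

In this assay, the group on an oxygen on an aromatic ring has now been varied three ways, and neither new step at that place leaves the scatter: a 1.2-fold higher number from compound 3 to compound 4 (0.08 log units; within the scatter), and a 1.8-fold higher number from compound 2 to compound 4 (0.25 log units; within the scatter). Together with the earlier change from cyclopentyl to phenyl, this means that cyclopentyl, phenyl and benzyl cannot be told apart at this place, so the single earlier step now has support from a second aromatic group, one that carries its ring on a single carbon. Compound 4 also links the series to compound 1, since both carry benzyl on that oxygen and differ only in the group on a nitrogen on an aromatic ring, and there the change is modest but beyond the scatter, as a 3.1-fold lower number from compound 1 to compound 4 (0.49 log units; beyond the scatter) shows.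

Nothing shown accounts for either finding. On these data alone, it remains open whether an amine or a longer chain such as phenethyl on that oxygen would also stay within the scatter, and how the group on the nitrogen would compare without its chlorine.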